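The source may report more compounds than this note shows. Statements on the series, on what has been measured and on what is new or still open speak of the compounds shown alone.

Measured compounds:
- compound 1 `CC(=O)c1ccc(NC(=O)CSC(=S)N[C@H]2CCOC2=O)cc1` — in a functional assay on SMMC-7721 cells (Homo sapiens) for cytotoxicity, read by MTT assay, with a stated time of 72 h (on this read-out higher numbers stand for weaker inhibition and lower numbers for stronger inhibition), compound 1 gives > 128000 nM, a limit of the assay rather than a number.
- compound 2 `CCOC(=O)c1ccc(NC(=O)CSC(=S)N[C@H]2CCOC2=O)cc1` — in this assay compound 2 gives 64900 nM.
- compound 3 `O=C(CCl)Nc1ccc(C(=O)/C=C/c2ccc(Cl)cc2)cc1` — in this assay compound 3 gives 8160 nM.

Compound 3 stands at the lowest of the two numbers shown; compound 2 is the nearest and sits well above it. For the measured compounds named here, the only measured step is an at least 1.9-fold lower number from compound 1 to compound 2 (0.29 log units; that floor lies within the scatter), and it concerns the group on the carbonyl carbon of a different core, against the limit of compound 1 (the limit of > 128000 nM in this assay, at which 1 of the 3 values shown sits).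

Compound 4 `O=C(CSC(=S)N[C@H]1CCOC1=O)Nc1ccc(C(=O)/C=C/c2ccc(Cl)cc2)cc1` is compound 3 with a group of 10 heavy atoms (5 carbon, 1 nitrogen, 2 oxygen, 2 sulfur; one five-membered non-aromatic ring with 1 hetero atom) in place of one chlorine atom, on a saturated chain carbon bound to a carbonyl carbon. Going by the values given here, the group that enters is the one carried by compound 1 and compound 2, whose numbers are high; the core of compound 3 is kept, and no measured step covers this change on that core. The step of a 1.5-fold higher number from compound 3 to compound 4 (0.17 log units; within the scatter) is therefore an estimate with wide uncertainty, leaning toward a modest rise in the number. Compound 4 is expected at 12000 nM, between 3000 nM and 50000 nM.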

Compound 4, half-maximal inhibitory concentration: > 128000 nM
Compound 4: a limit, no number; the forecaster's own chance of this, stated with the estimate: 5%; middle value at least 10-fold (1.02 log units) from the limit.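

In this assay, the group with the five-membered non-aromatic ring, set in place of one chlorine atom on a saturated chain carbon bound to a carbonyl carbon, gives an at least 15-fold higher number from compound 3 to compound 4 (1.19 log units; beyond the scatter). So the chlorine atom at this position cannot be exchanged for this group without a large rise in the number, even though the rest of the structure is kept. Putting 2-(4-chlorophenyl)ethenyl in place of ethoxy on a carbonyl carbon gives an at least 1.9-fold higher number from compound 2 to compound 4 (0.29 log units; that floor lies within the scatter), and compound 4 gives a limit of the assay, as does compound 1, so the step joining those two cannot be read: the limit of > 128000 nM in this assay, at which 2 of the 4 values shown sit.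

From the compounds shown here alone, it remains open whether the whole entering group or only one part of it accounts for the rise. Going by these compounds, it is also open how a simple amine or a methoxy group at the same carbon would compare with the chlorine atom.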